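This account rests on a few compounds, and the source may have more. Where it says the series, first, only, none or still open, it means among the compounds named here.

Compound 1 `Nc1ncnc2c1ncn2C[C@@H]1C[C@H](CO)c2ccccc21` is the point of departure. In a functional assay on CCRF-CEM cells (Homo sapiens) (on this read-out lower numbers stand for stronger inhibition and higher numbers for weaker inhibition), compound 1 gives 24 ug/mL. Two relatives share its core: compound 2 `CCOc1ncnc2c1ncn2C[C@@H]1C[C@H](CO)c2ccccc21` gives 24 ug/mL, and compound 3 `CCCNc1ncnc2c1ncn2C[C@@H]1C[C@H](CO)c2ccccc21` gives 24 ug/mL. The change no change at the digits printed from compound 1 to compound 2 (within the scatter) and the change no change at the digits printed from compound 1 to compound 3 (within the scatter) show the read-out standing still, and no change at the digits printed from compound 2 to compound 3 (within the scatter) confirms it, so compound 1 sits level with both neighbours. Compound 4 `OC[C@H]1C[C@@H](Cn2cnc3c(NC4CC4)ncnc32)c2ccccc21` differs from compound 1 by cyclopropyl in place of hydrogen on a nitrogen on an aromatic ring. The nearest parallel is the step to compound 3, which puts propyl in place of hydrogen on a nitrogen on an aromatic ring and moved nothing beyond the scatter. A flat outcome is therefore expected, no change at the digits printed from compound 1 to compound 4 (within the scatter), with compound 4 estimated at 24 ug/mL, in a range from 12 ug/mL to 48 ug/mL.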

Compound 4, half-maximal inhibitory concentration: 24 ug/mL
Beside the measured number, compound 4's estimate shows no gap at the digits printed, and the stated range covers the measured number.
By their numbers in this assay, from the lowest: compounds 1, 2, 3 and 4 (each within the scatter of the next).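

In this assay, a closed three-membered ring on this nitrogen leaves the read-out flat (no change at the digits printed from compound 1 to compound 4 (within the scatter)), and the ring and the open propyl chain read alike (no change at the digits printed from compound 3 to compound 4 (within the scatter)). Cyclopropylamino and ethoxy on the aromatic carbon also read alike (no change at the digits printed from compound 2 to compound 4 (within the scatter)), so this position has now accepted a ring as well as open chains without any visible effect. No supporting measurement explains this flat response. On these data alone, whether a cyclohexyl or benzyl group on this nitrogen would shift the number remains open.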